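Replacing a Piperazine With an Aminophenol on a Shared Core

The compounds below may be only part of what the source reports. "The series", "measured", "known", "first", "only" and "open" are said of these compounds alone.

Compound 2 `COc1cc(/C=C/c2nc(N3CCN(C)CC3)c3sccc3n2)cc(OC)c1OC` was tested in a functional assay on L02 cells (Homo sapiens) for inhibition, read by Griess assay, with stated times of 1 h and 24 h; on this read-out lower numbers stand for stronger inhibition and higher numbers for weaker inhibition. Here compound 2 gives only a limit, > 1000000 nM, and no number. Compound 1 `CC(C)CNc1nc(/C=C/c2ccccc2)nc2ccsc12` also gives only a limit in this assay, > 1000000 nM. Both values sit at the limit of > 1000000 nM in this assay, at which 2 of the 2 values shown sit, so the measurements offer no foothold for judging any step. Compound 3 `COc1cc(/C=C/c2nc(Nc3ccc(O)cc3)c3sccc3n2)cc(OC)c1OC` differs from compound 2 in one place: (4-hydroxyphenyl)amino in place of 4-methylpiperazin-1-yl on an aromatic carbon. Among the measured compounds shown here, with no measured step to lean on, compound 3 is expected to stay near the same limit. The step of a number no higher from compound 2 to compound 3 (the limit leaves the size open) is expected to be none beyond the scatter. The estimate for compound 3 is 1000000 nM, between 100000 nM and 5000000 nM.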

Compound 3, half-maximal inhibitory concentration: > 1000000 nM
Compound 3 was reported as a limit; the forecaster's own chance of this, stated with the estimate: 75%; the middle value sits exactly at the limit.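

Compound 2 and compound 3 both give only a limit and not a number, so no step can be read between them: the limit of > 1000000 nM in this assay, at which 3 of the 3 values shown sit.

The compounds shown leave open what any change on the shared core does to inhibition.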